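This account rests on a few compounds, and the source may have more. Where it says the series, first, only, none or still open, it means among the compounds named here.

Compound 3 `CCCNC(=O)c1cc(Oc2ccc(NC(=O)c3cc4cccnc4n(-c4ccc(F)cc4)c3=O)cc2)ccn1` gives the lowest number of the three measured in a functional assay on HT-29 cells (Homo sapiens) for antiproliferative activity, read by MTT assay, with a stated time of 72 h (a higher number here means a weaker inhibitor, a lower number a stronger inhibitor), with 84 nM. Compound 2 `CCCNC(=O)c1cc(Oc2ccc(NC(=O)c3cc4cccnc4n(-c4ccccc4)c3=O)cc2)ccn1` gives 98 nM, and the step of a 1.2-fold lower number from compound 2 to compound 3 (0.07 log units; within the scatter) is within the scatter. Compound 1 `CNC(=O)c1cc(Oc2ccc(NC(=O)c3cc4cccnc4n(-c4ccc(Cl)cc4)c3=O)cc2)ccn1` carries the same 4-chlorophenyl group that compound 4 will carry but a methylamide instead of the propylamide, and in this assay compound 1 gives 390 nM; since two places differ between compound 1 and compound 3, nothing can be read from that pair alone about the chloro group.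

Compound 4 `CCCNC(=O)c1cc(Oc2ccc(NC(=O)c3cc4cccnc4n(-c4ccc(Cl)cc4)c3=O)cc2)ccn1` differs from compound 3 by chloro in place of fluoro on an aromatic carbon. For the measured compounds named here, the only measured step that bears on this position is the one from hydrogen to fluoro, which was within the scatter, so a small substituent change at this place has so far had no effect beyond the scatter. Compound 4 is therefore expected to give a number close to that of compound 3, with the step of a 1.2-fold higher number from compound 3 to compound 4 (0.08 log units; within the scatter) expected to stay within the scatter. The estimate for compound 4 in this assay is 100 nM, in a range from 40 nM to 250 nM.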

Compound 4, half-maximal inhibitory concentration: 390 nM
The estimate for compound 4 lay 3.9-fold (0.59 log units) below the measured number, and the stated range ends below it.
By their numbers in this assay, from the lowest: compounds 3 and 2 (each within the scatter of the next); then compounds 1 and 4 (each within the scatter of the next).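

In this assay this place on the ring no longer looks indifferent to substitution: the earlier hydrogen-to-fluoro step stayed within the scatter, whereas chloro gives a clear change against both fluoro (with a 4.6-fold higher number from compound 3 to compound 4 (0.67 log units; beyond the scatter)) and hydrogen (with a 4.0-fold higher number from compound 2 to compound 4 (0.60 log units; beyond the scatter)). The amide chain, which compound 1 alone could not separate from the chloro group, now reads apart from it: with 4-chlorophenyl in place, ethyl in place of hydrogen on the chain carbon leaves the number unmoved (with no change at the digits printed from compound 1 to compound 4 (within the scatter)). No measurement given here accounts for the difference between chloro and fluoro.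

On these data alone, whether a bromo, methyl or methoxy group at this place would track chloro or fluoro remains open. So does whether the chain length is equally silent with a 4-fluorophenyl group, and what a longer chain or an amine on the amide would do.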